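One More Chain Carbon Before the Dicarboxymethyl Group

This account rests on a few compounds, and the source may have more. Where it says the series, first, only, none or still open, it means among the compounds named here.

Within the data shown here, compound 2 `CC1OC(OC2CCCCC2OCCCCCC(C(=O)O)C(=O)O)C(O)C(O)C1O` is one of two compounds measured here. In a functional assay on HL-60 cells (Homo sapiens) for inhibition (on this read-out lower numbers stand for stronger inhibition and higher numbers for weaker inhibition), compound 2 gives only a limit of the assay, > 5000000 nM. Compound 1 `CC1OC(OC2CCCCC2OCCCC(C(=O)O)C(=O)O)C(O)C(O)C1O` likewise gives only a limit in this assay, > 5000000 nM. Among the measured compounds shown here, the single measured step, a step that the two limits leave unreadable from compound 1 to compound 2, cannot be read because of the limit of > 5000000 nM in this assay, at which 2 of the 2 values shown sit. Compound 3 `CC1OC(OC2CCCCC2OCCCCCCC(C(=O)O)C(=O)O)C(O)C(O)C1O` differs from compound 2 by 2,2-dicarboxyethyl in place of dicarboxymethyl on a saturated chain carbon, five bonds along the chain from an oxygen on a saturated carbon. No readable step bears on this change, so no direction beyond the scatter can be expected. Compound 3 is expected to give 5000000 nM, within 1000000 nM to 50000000 nM. That expectation means a step of a number no higher from compound 2 to compound 3 (the limit leaves the size open), most probably again ending only at a limit.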

Compound 3, half-maximal inhibitory concentration: > 5000000 nM
Compound 3 gave a limit, no number (the forecaster's own chance of this, stated with the estimate: 85%); the middle value lies on the limit itself.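

No step among compound 1, compound 2 and compound 3 can be read, because their values are limits, not numbers: the limit of > 5000000 nM in this assay, at which 3 of the 3 values shown sit.

The compounds shown leave open how strongly, if at all, each inhibits in this assay.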